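The source may report more compounds than this note shows. Statements on the series, on what has been measured and on what is new or still open speak of the compounds shown alone.

Working notes on the series in an ADME assay on HepG2 cells (Homo sapiens) for cytotoxicity, read by MTT assay, with a stated time of 72 h; on this read-out lower numbers stand for higher toxicity in this test and higher numbers for lower toxicity in this test. Compound 1 (`O=[N+]([O-])c1c(CS(=O)(=O)c2ccccc2)nc2c(-c3ccccc3)cc(Cl)cn12`) gives > 15600 nM, which is a limit. Compound 2 (`O=[N+]([O-])c1c(CS(=O)(=O)c2ccccc2)nc2c(-c3ccc(O)cc3)cc(Cl)cn12`) gives > 12500 nM, also a limit. Compound 3 (`O=[N+]([O-])c1c(CS(=O)(=O)c2ccccc2)nc2c(-c3ccc(C(F)(F)F)cc3)cc(Cl)cn12`) gives > 3900 nM, again a limit, so its standing is known only as a limit, and the same holds for the other two values.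

Compound 4 (`O=[N+]([O-])c1c(CS(=O)(=O)c2ccccc2)nc2c(-c3cccc(C(F)(F)F)c3)cc(Cl)cn12`) is the next case, and the change from compound 3 is 3-(trifluoromethyl)phenyl in place of 4-(trifluoromethyl)phenyl on an aromatic carbon. The two structures have the same atoms, joined differently, with 3-(trifluoromethyl)phenyl entering where 4-(trifluoromethyl)phenyl leaves.

The closest measured evidence is a step that the two limits leave unreadable from compound 1 to compound 3, together with a step that the two limits leave unreadable from compound 2 to compound 3. The remaining one is a step that the two limits leave unreadable from compound 1 to compound 2. Going by the values given here, none of these has a readable size, and no compound so far carries a number, so no step size can be carried over. No shift beyond the scatter is expected in this assay. The expected change is a step that the limit leaves unreadable from compound 3 to compound 4, with no direction claimed. The estimated value for compound 4 is 5000 nM, with an expected range from 2500 nM to 16000 nM.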

Compound 4, half-maximal cytotoxic concentration: > 12500 nM
Compound 4 ended at the assay's limit; the forecaster's own chance of this, stated with the estimate: 80%; middle value at least 2.5-fold (0.39 log units) from the limit.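

Compound 4 gives > 12500 nM, which is a limit. No step can be read from compound 4 to compound 1, compound 2 or compound 3, as all of them also carry limits. From the compounds shown here alone, whether these four compounds differ at all in this assay remains open.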